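The source may report more compounds than this note shows. Statements on the series, on what has been measured and on what is new or still open speak of the compounds shown alone.

Working notes on the series. Among the measured compounds shown here, in a functional assay on HCC827 cells (Homo sapiens) for inhibition, read by fluorescence and resazurin assay, with a stated time of 72 h (on this read-out lower numbers stand for stronger inhibition of growth and higher numbers for weaker inhibition of growth), compound 1 `COc1ccccc1-c1ccc(Nc2nc(N[C@H]3CC[C@H](N)CC3)nc3c2ncn3C2CCCC2)cc1` gives 2300 nM, the lower of the two numbers so far. Compound 2 `OCCCNc1nc(Nc2ccc(Oc3nccs3)cc2)c2ncn(C3CCCC3)c2n1` gives 6490 nM, higher by more than the usual scatter. The next structure is compound 3 `N[C@H]1CC[C@H](Nc2nc(Nc3ccc(Oc4ccc(Br)cn4)cc3)c3ncn(C4CCCC4)c3n2)CC1`, which carries (5-bromopyridin-2-yl)oxy in place of 2-methoxyphenyl on an aromatic carbon, para to a large group ((5-bromopyridin-2-yl)oxy in place of 2-methoxyphenyl on an aromatic carbon). For the measured compounds named here, no measured pair isolates this change, so the direction rests on thin evidence. Compound 2, at 6490 nM, also has an oxygen-linked aromatic ring, but it differs from compound 1 in more than one place and offers only a weak guide. No step beyond the scatter is expected in this assay, and the estimated step is a 1.3-fold lower number from compound 1 to compound 3 (0.11 log units; within the scatter). For compound 3 the estimated value is 1800 nM, with an expected range of 600 nM to 5500 nM.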

Compound 3, concentration for 50% growth inhibition: 3730 nM
Estimate against measurement, compound 3: 2.1-fold (0.32 log units) below; the range from low to high includes it.
By their numbers in this assay, from the lowest: compounds 1, 3 and 2 (each within the scatter of the next, the first and the last beyond it).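

In this assay, among the compounds shown here, the exchange of 2-methoxyphenyl for (5-bromopyridin-2-yl)oxy gives the first single-place step, a 1.6-fold higher number from compound 1 to compound 3 (0.21 log units; within the scatter) and so within the scatter. On this aromatic carbon, para to a large group, the carbon-only aromatic ring can thus give way to an oxygen-linked six-membered aromatic ring with 1 hetero atom and bromine without a step beyond the scatter. No measured evidence accounts for this result or separates the contributions of the oxygen link, the ring nitrogen and the bromine.

Still open, going by these compounds, is whether a carboxylic acid, a primary amine or a simple phenoxy group at this place would give a step beyond the scatter. Compound 2 differs from both compounds in more than one place, so the effect of its other groups cannot be read.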